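The source may report more compounds than this note shows. Statements on the series, on what has been measured and on what is new or still open speak of the compounds shown alone.

Measured so far:
compound 1, `CC(=O)N(C)CC(O)CN1CCC(CNC(=O)c2cccc3[nH]c(C(C)C)nc23)CC1`, giving 64% in a functional assay for agonist activity at 5-hydroxytryptamine receptor 4 (Homo sapiens), read by cAMP accumulation; a higher number here means a larger maximal response, a lower number a smaller maximal response
compound 2, `CC(C)c1nc2c(C(=O)NCC3CCN(CCN4CCN(S(C)(=O)=O)CC4)CC3)cccc2[nH]1`, giving 64%

Compound 2 stands level with compound 1 at the digits shown; the one measured step, no change at the digits printed from compound 1 to compound 2 (within the scatter), lies within the scatter of this assay. Compound 3, `CC(=O)N1CCC(CN2CCC(CNC(=O)c3cccc4[nH]c(C(C)C)nc34)CC2)CC1`, has not been measured. It differs from compound 2 as follows: 1-acetylpiperidin-4-yl in place of (4-(methylsulfonyl)piperazin-1-yl)methyl on a saturated chain carbon bound to an amine nitrogen in a ring. Among the compounds with values here, no measured step covers this particular exchange. Within the data shown here, the only step available, no change at the digits printed from compound 1 to compound 2 (within the scatter), swapped one group for another at the same place and produced no change beyond the scatter, so the guidance it gives is indirect and weak. The step expected in this assay is therefore a number 2 percentage points lower from compound 2 to compound 3 (within the scatter), nothing beyond the scatter, with a wider range than usual to allow for the untested group. Compound 3 is estimated at 62%, within 48% to 76%.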

Compound 3, intrinsic activity: the largest response reached, in percent of the reference agonist's: 87%
For compound 3 the middle estimate is 25 percentage points below the measured one; measured number above the stated range.
By their numbers in this assay, from the lowest: compounds 1 and 2 (each within the scatter of the next); then compound 3.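

Until now, the groups compared on a saturated chain carbon bound to an amine nitrogen in a ring had left this assay unchanged, so this place could have seemed indifferent to what it carries. Putting 1-acetylpiperidin-4-yl there in place of (4-(methylsulfonyl)piperazin-1-yl)methyl gives a number 23 percentage points higher from compound 2 to compound 3 (beyond the scatter) and in place of 2-(acetyl(methyl)amino)-1-hydroxyethyl gives a number 23 percentage points higher from compound 1 to compound 3 (beyond the scatter), so the maximal response does depend on the group at this place. No measurement shown here explains this rise.

The exchange from compound 2 to compound 3 alters both the ring and the group on its nitrogen, so the compounds shown do not tell which of the two matters. A 1-(methylsulfonyl)piperidin-4-yl group or an unsubstituted piperidin-4-yl group at the same place would help to separate them.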